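The source may hold more compounds than are shown below. What is called first, only, known or untested is meant among the compounds shown, and "the series" means these compounds.

Compound 3 `Cc1ccc(Nc2nn(-c3ccc([N+](=O)[O-])cc3)c3nc(Nc4ccccc4)n(-c4ccccc4)c(=O)c23)cc1` was tested in a functional assay on the whole organism (strain Wistar albino) for inhibition, with Rattus norvegicus as the target, read by paw edema, with a stated time of 2 h, at a dose of 25 mg/kg by the oral route (a higher number here means more inhibition at the dose given (going by the name of the read-out), a lower number less inhibition), where it gives 39.8%. For the measured compounds named here, that is the lowest of the three numbers measured so far. Compound 2 `Cc1ccc(Nc2nn(-c3ccccc3)c3nc(Nc4ccccc4)n(-c4ccccc4)c(=O)c23)cc1` gives 53.4% in this assay, and compound 1 `NS(=O)(=O)c1ccc(-n2nc(Nc3ccc([N+](=O)[O-])cc3)c3c(=O)n(-c4ccccc4)c(Nc4ccccc4)nc32)cc1`, which carries a 4-sulfamoylphenyl group, gives 55.3%. Going by the values given here, the one change already measured in a single place is the step of a number 13.6 percentage points lower from compound 2 to compound 3 (beyond the scatter), so adding a nitro group lowered the inhibition by a modest amount beyond the scatter.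

Compound 4 `Cc1ccc(Nc2nn(-c3ccc(S(N)(=O)=O)cc3)c3nc(Nc4ccccc4)n(-c4ccccc4)c(=O)c23)cc1` differs from compound 3 by sulfamoyl in place of nitro on an aromatic carbon. Among the compounds with values here, the nitro that went with the lower number in the step from compound 2 to compound 3 is thus exchanged for a sulfamoyl, and the one measured compound bearing a sulfamoyl, compound 1, stands among the higher values. Taken together, a rise back toward the level of compounds 1 and 2 is expected, though no measured step shows this exact exchange, so the range is kept wide. The expected step is a number 12.2 percentage points higher from compound 3 to compound 4 (beyond the scatter). For compound 4 the estimate in this assay is 52%, with a likely range from 40% to 64%.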

Compound 4, a percentage reported as inhibition, in the whole organism at one dose (the size of the read-out at that dose, not a potency): 63.4%
Beside the measured number, compound 4's estimate is 11.4 percentage points below it; measured number inside the range.
By their numbers in this assay, from the lowest: compound 3; then compounds 2, 1 and 4 (each within the scatter of the next).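

In this assay, the direct exchange of 4-nitrophenyl for 4-sulfamoylphenyl gives a number 23.6 percentage points higher from compound 3 to compound 4 (beyond the scatter) and so compares the two groups at this place on the ring, which the earlier step from hydrogen to nitro could not do. Set against the plain ring, sulfamoyl in place of hydrogen gives a number 10 percentage points higher from compound 2 to compound 4 (within the scatter) in the same test, so only the nitro compound stands apart from the unsubstituted compound here. With the sulfamoyl held constant, methyl in place of nitro on an aromatic carbon gives a number 8.1 percentage points higher from compound 1 to compound 4 (within the scatter) and so does not separate those two compounds.

Nothing measured here explains the difference between nitro and sulfamoyl. Going by these compounds, whether an amine or a carboxylic acid at this place would match the sulfamoyl remains open.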